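Trifluoromethyl to Bromo: A Single Swap

A few compounds are considered here, and "the series" means these few. Any claim that something is new, unique, unknown or untested is made for them only; others in the source may bear on it.

Within the data shown here, the compounds here are compared in a functional assay on CCRF-CEM cells (Homo sapiens) for inhibition, read by MTT assay, with a stated time of 72 h (a lower number here means a stronger inhibitor, a higher number a weaker inhibitor), and only two numbers exist so far. Compound 1 (`COc1cc(NC(C)CCCNC(=O)Nc2cccc(F)c2)c2ncccc2c1`) gives 21000 nM and compound 2 (`COc1cc(NC(C)CCCNC(=O)NNC(=O)Nc2ccc(C(F)(F)F)cc2)c2ncccc2c1`) gives 18000 nM in this test of the same cells. These two values lie within the usual scatter of each other, so compound 2 cannot be separated from compound 1 on the numbers shown.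

Compound 3 (`COc1cc(NC(C)CCCNC(=O)NNC(=O)Nc2ccc(Br)cc2)c2ncccc2c1`) has not been measured yet. It differs from compound 2 in one place, with bromo in place of trifluoromethyl on an aromatic carbon, para to a large group (bromo in place of trifluoromethyl on an aromatic carbon). Among the measured compounds shown here, no measured pair shows this swap directly, so the data give no direction for it. Compound 1 and compound 2 differ by more than this one group, yet compound 1 at 21000 nM and compound 2 at 18000 nM stay close. The expected step of no change at the digits printed from compound 2 to compound 3 (within the scatter) is therefore small, with nothing expected beyond the scatter in this assay here. Compound 3 is estimated at 18000 nM with an expected range of 8000 nM to 40000 nM around that figure.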

Compound 3, half-maximal inhibitory concentration: 110000 nM
Estimate against measurement, compound 3: 6.1-fold (0.79 log units) below; the whole stated range lies below it.
By their numbers in this assay, from the lowest: compounds 2 and 1 (each within the scatter of the next); then compound 3.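

In this assay, the group on this aromatic carbon turns out to matter: putting bromo in place of trifluoromethyl leaves the rest of the molecule untouched and still weakens it (a 6.1-fold higher number from compound 2 to compound 3 (0.79 log units; beyond the scatter)), something the two earlier numbers alone could not reveal about this position. The wider change, ((4-bromophenyl)carbamoyl)amino in place of 3-fluorophenyl on an amide-type nitrogen, points the same way (a 5.2-fold higher number from compound 1 to compound 3 (0.72 log units; beyond the scatter)), so compound 3 stands apart as the weaker inhibitor, while compound 1 and compound 2 stay within the scatter of each other. No measurement in hand explains the difference between bromo and trifluoromethyl at this position.

As far as these compounds go, only these two groups can be compared on this aromatic carbon, so it remains open whether trifluoromethyl is unusually well tolerated here or bromo is unusually poor. Among these compounds, a chloro group, a methoxy group or an amine at the same place could settle that, and it also remains open whether the same swap would weaken a compound that carries a different chain from the one shared by compound 2 and compound 3.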